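A few compounds are considered here, and "the series" means these few. Any claim that something is new, unique, unknown or untested is made for them only; others in the source may bear on it.

In an ADME assay on CHO-K1 cells (Cricetulus griseus) for cytotoxicity, read by MTT assay, with a stated time of 24 h (on this read-out higher numbers stand for weaker inhibition and lower numbers for stronger inhibition), compound 1 `CCCCCCCCCCCCCCCCCC(=O)Nc1nnc(S[C@@H]2O[C@H](CO)[C@H](O)[C@H](O)[C@H]2O)s1` has no number to stand on, since compound 1 is reported as "not active" (no number reported). Compound 2 `CCCCCC(=O)Nc1nnc(S[C@@H]2O[C@H](COC(C)=O)[C@H](OC(C)=O)[C@H](OC(C)=O)[C@H]2OC(C)=O)s1` gives 24400 nM, and compound 3 `CCCCCCCCCCCCCCCC(=O)Nc1nnc(S[C@@H]2O[C@H](COC(C)=O)[C@H](OC(C)=O)[C@H](OC(C)=O)[C@H]2OC(C)=O)s1` gives 90400 nM. Compound 4 `C=CCCCCCCCCC(=O)Nc1nnc(S[C@@H]2O[C@H](CO)[C@H](O)[C@H](O)[C@H]2O)s1` differs from compound 1 by vinyl in place of nonyl on a saturated chain carbon, eight bonds along the chain from a carbonyl carbon. For the measured compounds named here, one measured step bears on this change, the modest lengthening a 3.7-fold higher number from compound 2 to compound 3 (0.57 log units; beyond the scatter), which lies beyond the scatter, although both of its compounds also differ from compound 1 elsewhere. Read in reverse, that step leads to the expectation of a modest move towards a lower number, with no number for compound 1 to measure it from. The estimated value for compound 4 is 80000 nM, within an expected range of 25000 nM to 250000 nM.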

Compound 4, half-maximal inhibitory concentration: "not active" (no number reported)
The entry for compound 4 holds no number; there is nothing to compare the estimate with.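

In this assay compound 1 and compound 4 are both reported as not active, so no step can be read between them. Whether vinyl in place of nonyl shifts this read-out stays open, and nothing shown here bears on the result.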